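Methoxy for 4-chlorophenyl: estimating compound 3

The compounds below may be only part of what the source reports. "The series", "measured", "known", "first", "only" and "open" are said of these compounds alone.

Measured so far:
- compound 1, `CCOC(=O)/C=C1/C(=O)N2[C@@H]1SC(C)(C)[C@@H]2C(=O)OC(c1ccccc1)c1ccccc1`: 7000 nM
- compound 2, `CC1(C)S[C@@H]2/C(=C\C(=O)c3ccc(Cl)cc3)C(=O)N2[C@H]1C(=O)OC(c1ccccc1)c1ccccc1`: 48600 nM

In a functional assay on A-375 cells (Homo sapiens) for cytotoxicity, read by MTT assay, with a stated time of 48 h (on this read-out lower numbers stand for stronger inhibition and higher numbers for weaker inhibition), compound 2 gives the highest of the two numbers, with compound 1 the nearer one at 7000 nM. Compound 3, `COC(=O)/C=C1/C(=O)N2[C@@H]1SC(C)(C)[C@@H]2C(=O)OC(c1ccccc1)c1ccccc1`, differs from compound 2 by methoxy in place of 4-chlorophenyl on a carbonyl carbon. Among the compounds with values here, the one measured step that bears on this is a 6.9-fold higher number from compound 1 to compound 2 (0.84 log units; beyond the scatter), where ethoxy gave way to 4-chlorophenyl at the same carbonyl carbon; the change to compound 3 runs the other way, with methoxy entering. A drop beyond the scatter, close to the size of that step, is therefore expected: a 6.9-fold lower number from compound 2 to compound 3 (0.84 log units; beyond the scatter). Compound 3 is estimated at 7000 nM, between 2500 nM and 20000 nM.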

Compound 3, half-maximal inhibitory concentration: 24600 nM
Compound 3: middle estimate off by 3.5-fold (0.55 log units), on the low side, and the stated range ends below it.
By their numbers in this assay, from the lowest: compound 1; then compounds 3 and 2 (each within the scatter of the next).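

In this assay, swapping the ring-bearing 4-chlorophenyl for methoxy on this carbonyl carbon leaves the two compounds within the scatter of each other: a 2.0-fold lower number from compound 2 to compound 3 (0.30 log units; within the scatter). Yet the loss of a single methyl from the ester chain does register, as a 3.5-fold higher number from compound 1 to compound 3 (0.55 log units; beyond the scatter), so ethoxy separates from methoxy here even though a much larger swap does not separate methoxy from 4-chlorophenyl. Nothing available explains this difference.

The ethoxy and methoxy contrast rests on one pair of compounds. As far as these compounds go, whether a longer chain such as propoxy, or an amine, on this carbonyl carbon would extend it remains open.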